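This account rests on a few compounds, and the source may have more. Where it says the series, first, only, none or still open, it means among the compounds named here.

Compound 1 `COc1cccc(/C=C2\CCC/C(=C\c3cccc(OC)c3OC)C2=O)c1`, compound 2 `COc1cccc(/C=C2\CCC/C(=C\c3cccc(O)c3)C2=O)c1OC` and compound 3 `COc1cc(/C=C2\CCC/C(=C\c3cccc(OC)c3OC)C2=O)ccc1O` were tested in an ADME assay on NHDF cells (Homo sapiens) for cytotoxicity, read by MTT assay, with a stated time of 72 h; a higher number here means a weaker inhibitor, a lower number a stronger inhibitor. Compound 1 gives 16400 nM, compound 2 gives 19300 nM and compound 3 gives 14300 nM; the three numbers lie within the scatter of one another, as shown by a 1.2-fold higher number from compound 1 to compound 2 (0.07 log units; within the scatter), a 1.1-fold lower number from compound 1 to compound 3 (0.06 log units; within the scatter) and a 1.3-fold lower number from compound 2 to compound 3 (0.13 log units; within the scatter). Compound 4 `COc1cccc(/C=C2\CCC/C(=C\c3ccc(O)c(O)c3)C2=O)c1OC` has not yet been measured. It differs from compound 3 by hydrogen in place of methyl on an oxygen on an aromatic ring, the same change that turns compound 1 into compound 2, (hydrogen in place of methyl on an oxygen on an aromatic ring). The cores of compound 1 and compound 3 differ by hydroxy in place of hydrogen on an aromatic carbon. Because that earlier step a 1.2-fold higher number from compound 1 to compound 2 (0.07 log units; within the scatter) stayed within the scatter, a step of similar size is expected here. The expected step is a 1.2-fold higher number from compound 3 to compound 4 (0.08 log units; within the scatter). Compound 4 is estimated at 17000 nM, most likely between 9000 nM and 32000 nM.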

Compound 4, half-maximal inhibitory concentration: 17900 nM
Compound 4: the middle estimate sits 1.1-fold (0.02 log units) below what was measured, within the range that was stated.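

In this assay, hydrogen in place of methyl on an oxygen on an aromatic ring gives a 1.3-fold higher number from compound 3 to compound 4 (0.10 log units; within the scatter), and this small step agrees with the one seen on the other core: the same change on two cores in this assay, a 1.2-fold higher number (0.07 log units; within the scatter) from compound 1 to compound 2 and a 1.3-fold higher number (0.10 log units; within the scatter) from compound 3 to compound 4, 1.1-fold (0.03 log units) apart, within the scatter of two such steps. Hydroxy in place of hydrogen on an aromatic carbon gives a 1.1-fold lower number from compound 2 to compound 4 (0.03 log units; within the scatter), which also agrees with its earlier counterpart, while the replacement of a whole aromatic group gives a 1.1-fold higher number from compound 1 to compound 4 (0.04 log units; within the scatter): the same change on two cores in this assay, a 1.1-fold lower number (0.06 log units; within the scatter) from compound 1 to compound 3 and a 1.1-fold lower number (0.03 log units; within the scatter) from compound 2 to compound 4, 1.1-fold (0.03 log units) apart, within the scatter of two such steps. So each change stays within the scatter on both cores, which shows that neither has a measurable effect here, but not that either would stay this small on a different core.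

All the groups varied here are methoxy and hydroxy. Going by these compounds, what an amine or a carboxylic acid would do on these aromatic rings remains open.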